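Estimating compound 4 from three measured neighbours

The source may hold more compounds than are shown below. What is called first, only, known or untested is meant among the compounds shown, and "the series" means these compounds.

Of the compounds shown here, three sharing one core have been tested in an ADME assay on microsomes from liver (Mus musculus) for metabolic stability, read by LC-MS, with a stated time of 30 min, tested at 1 uM; a lower number here means that less of the compound is left, a higher number that more of the compound is left. Compound 1 (`O=C(NCc1ccc(S(=O)(=O)c2ccccc2)cc1)c1cc2ncccc2s1`) gives 1.6%. Compound 2 (`O=C(NCc1ccc(S(=O)(=O)c2ccccc2)cc1)c1nc2ccncc2s1`) gives 26%. Compound 3 (`O=C(NCc1ccc(S(=O)(=O)c2ccccc2)cc1)c1ccc2nccn2c1`) gives 18%.

Only one of the two gaps around compound 3 is a real one. The data show a number 16.4 percentage points higher from compound 1 to compound 3 (beyond the scatter), but also a number 8 percentage points lower from compound 2 to compound 3 (within the scatter), so compound 3 and compound 2 cannot be told apart here.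

Compound 4 (`O=C(NCc1ccc(S(=O)(=O)c2ccccc2)cc1)c1cn2ccnc2cn1`) has not been measured yet. The change that leads to it is a group of 9 heavy atoms (6 carbon, 3 nitrogen; one five-membered aromatic ring with 2 hetero atoms, one six-membered aromatic ring with 2 hetero atoms) in place of a group of 9 heavy atoms (7 carbon, 2 nitrogen; one five-membered aromatic ring with 2 hetero atoms, one six-membered aromatic ring with 1 hetero atom), on a carbonyl carbon. The six-membered aromatic ring thus goes from 1 hetero atom to 2.

Among the measured compounds shown here, the closest precedent is a number 24.4 percentage points higher from compound 1 to compound 2 (beyond the scatter), where the group also loses a carbon and gains a nitrogen, though in its five-membered aromatic ring. The step of a number 16.4 percentage points higher from compound 1 to compound 3 (beyond the scatter) is a weaker guide, since that swap also removes the sulfur. For the measured compounds named here, no measured step adds a hetero atom to the six-membered ring, so this single precedent supports only a cautious forecast.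

What is expected in this assay is therefore a number 12 percentage points higher from compound 3 to compound 4 (beyond the scatter), a smaller step than the precedent and an uncertain one. For compound 4 the estimated value is 30%, with an expected range of 12% to 50%.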

Compound 4, percent of the compound remaining: 13%
For compound 4 the middle estimate is 17 percentage points above the measured one; measured number inside the range.
By their numbers in this assay, from the lowest: compound 1; then compounds 4, 3 and 2 (each within the scatter of the next, the first and the last beyond it).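

In this assay, the step that adds a hetero atom to the six-membered aromatic ring, on the same carbonyl carbon, gives (a number 5 percentage points lower from compound 3 to compound 4 (within the scatter)), so this change cannot be told apart from no change at all, and the clear gain of the earlier step (a number 24.4 percentage points higher from compound 1 to compound 2 (beyond the scatter)) does not carry over to it. The group of compound 4 still has real gaps on both sides (a number 11.4 percentage points higher from compound 1 to compound 4 (beyond the scatter); a number 13 percentage points lower from compound 2 to compound 4 (beyond the scatter)), even though compound 3 stays within the scatter of both compound 2 and compound 4, so small steps that cannot be read singly can still add up to a readable gap across the set. No measurement at hand offers a reason for any of these differences.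

Among the compounds shown here, only one group with a second hetero atom in its six-membered ring appears here, so it stays open whether other such groups, or the same ring change made on the sulfur-containing group of compound 2, would behave alike. Also open, from the compounds shown here alone, is what a methyl, a fluorine or an amine added to the group on the carbonyl carbon would do to the amount of compound left.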